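Propyl in place of cyclopropyloxy on the shared core

The source may report more compounds than this note shows. Statements on the series, on what has been measured and on what is new or still open speak of the compounds shown alone.

Compound 1 `c1ccc(OC2CC2)c(OCC2=NCCN2)c1` was measured in an assay on isolated protein for binding affinity to Alpha-2B adrenergic receptor (Homo sapiens) (a higher number here means a weaker inhibitor, a lower number a stronger inhibitor), and gave 794 nM. Among the measured compounds shown here, of the two compounds measured so far it carries the higher number, but compound 2 `CCCc1ccccc1OC(C)C1=NCCN1`, which gives 537 nM in this assay, lies within the usual scatter of it, so the two numbers cannot be told apart. Compound 3 `CCCc1ccccc1OCC1=NCCN1` has not yet been measured in this assay. It differs from compound 1 in one place: propyl in place of cyclopropyloxy on an aromatic carbon. For the measured compounds named here, no step between two measured compounds covers this exchange, so the expected size of the move rests on the two numbers alone. Compound 2 also carries the propyl group and gives a number in the same range, so the step from compound 1 to compound 3 is expected to be small, a 1.6-fold lower number from compound 1 to compound 3 (0.20 log units; within the scatter), not clearly beyond the scatter. Compound 3 is estimated to give 500 nM in this assay, with a range from 150 nM to 1600 nM.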

Compound 3, inhibition constant: 550 nM
Compound 3: middle estimate off by 1.1-fold (0.04 log units), on the low side, within the range that was stated.
By their numbers in this assay, from the lowest: compounds 2, 3 and 1 (each within the scatter of the next).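

In this assay the exchange of cyclopropyloxy for propyl on the aromatic carbon gives a 1.4-fold lower number from compound 1 to compound 3 (0.16 log units; within the scatter) and so stays within the scatter: at this position, neither the oxygen nor the three-membered ring of cyclopropyloxy is shown to matter for this read-out. Compound 3 also isolates the methyl on the saturated chain carbon, which the earlier pair could not do, and hydrogen in its place gives a 1.0-fold higher number from compound 2 to compound 3 (0.01 log units; within the scatter) with no change that can be told from the scatter. No measurement given here accounts for either step. As far as these compounds go, whether an amine, a hydroxyl or a longer chain such as butyl on the aromatic carbon would move the number beyond the scatter stays open. So does whether ethyl in place of that methyl would do so.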